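Pyrazole series: acetyl for dimethylamino on the pendant phenyl

A few compounds are considered here, and "the series" means these few. Any claim that something is new, unique, unknown or untested is made for them only; others in the source may bear on it.

Measured compounds:
compound 1 `COc1cc(C)cc(-c2c(-c3ccnc(-c4ccc(N(C)C)cc4)c3)cnn2CC#N)c1` — 66.9 nM
compound 2 `Cc1cc(O)cc(-c2nn(CC#N)cc2-c2ccnc(-c3ccc(Oc4ccccc4)cc3)c2)c1` — 6840 nM

Within the data shown here, in a functional assay on MDA-MB-435 cells (Homo sapiens) for inhibition, read by sulforhodamine B assay, with a stated time of 48 h (a higher number here means a weaker inhibitor of growth, a lower number a stronger inhibitor of growth), compound 1 gives 66.9 nM, the lowest of the two numbers; compound 2 gives 6840 nM, a gap beyond the scatter, though the two differ in more than one place and no single step between them is defined.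

Compound 3 `COc1cc(C)cc(-c2c(-c3ccnc(-c4ccc(C(C)=O)cc4)c3)cnn2CC#N)c1` keeps the core of compound 1 with one change: acetyl in place of dimethylamino on an aromatic carbon. Among the measured compounds shown here, no measured pair shows this exchange, so the expectation rests on compound 1 alone.

A modest weakening, beyond the scatter, is expected, a 3.0-fold higher number from compound 1 to compound 3 (0.48 log units; beyond the scatter).

Compound 3 is estimated at 200 nM in this assay, in the range 50 nM to 800 nM.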

Compound 3, concentration for total growth inhibition: > 100000 nM
Compound 3: a limit, no number; the forecaster's own chance of this, stated with the estimate: 5%; middle value at least 500-fold (2.69 log units) away from the limit.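

In this assay, among these compounds, the change from 4-(dimethylamino)phenyl to 4-acetylphenyl gives an at least 1400-fold higher number from compound 1 to compound 3 (3.17 log units; beyond the scatter), so this position is far more sensitive to the group it carries than the earlier compounds could show. The two groups match in heavy atoms and hydrogen-bond acceptors, so those counts do not track the result in this pair. The reading for compound 3 is a limit of the assay and not a number: the limit of > 100000 nM in this assay, at which 1 of the 3 values shown sits.

On these data alone, whether a simple amino group, a morpholine or a methoxy group at this position would stay near compound 1 remains open. A single pair cannot show which feature of dimethylamino matters, and it gives no cause for the step.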